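The source may hold more compounds than are shown below. What is called first, only, known or untested is meant among the compounds shown, and "the series" means these compounds.

Measured compounds:
compound 1 `COc1cccc(C(=O)N(C)/N=C/c2ccc(OC)c(OC)c2)c1` — in a functional assay on the whole organism (strain A/J) for inhibition, with Mus musculus as the target, with stated times of 1 h and 18 h, at a dose of 100 umol/kg by the oral route (a lower number here means less inhibition, a higher number more inhibition at the dose given (going by the name of the read-out)), compound 1 gives 69%
compound 2 `COc1ccc(C(=O)N(C)/N=C/c2ccc(OC)c(OC)c2)cc1` — in this assay compound 2 gives 62%
compound 3 `COc1ccc(/C=N/N(C)C(=O)c2ccccc2)cc1OC` — in this assay compound 3 gives 51%

Compound 3 holds the lowest of the three numbers. Both steps that lead to it run downward and beyond the scatter: a number 18 percentage points lower from compound 1 to compound 3 (beyond the scatter) and a number 11 percentage points lower from compound 2 to compound 3 (beyond the scatter), each with a hydrogen in place of methoxy on an aromatic carbon of the ring attached to the carbonyl. Between the two methoxy-bearing compounds the step of a number 7 percentage points lower from compound 1 to compound 2 (within the scatter) stays within the scatter, so their two values are not told apart.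

Compound 4 `COc1ccc(/C=N/N(C)C(=O)c2ccc(Cl)cc2)cc1OC` differs from compound 3 by chloro in place of hydrogen on an aromatic carbon. Within the data shown here, no measured step places a chloro on any ring. Among the measured compounds shown here, the steps that bear on the same ring, a number 18 percentage points lower from compound 1 to compound 3 (beyond the scatter) and a number 11 percentage points lower from compound 2 to compound 3 (beyond the scatter), only show that a methoxy-bearing ring on the carbonyl side went with a modestly higher number than the bare phenyl of compound 3. Whether a chloro on that ring does the same is not known from these three compounds. The expectation is therefore a small upward step, a number 7 percentage points higher from compound 3 to compound 4 (within the scatter), which may not reach beyond the scatter. Compound 4 is expected to give 58%, with a range from 40% to 75%.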

Compound 4, a percentage reported as inhibition, in the whole organism at one dose (the size of the read-out at that dose, not a potency): 72%
Compound 4: middle estimate off by 14 percentage points, on the low side; measured number inside the range.
By their numbers in this assay, from the lowest: compound 3; then compounds 2, 1 and 4 (each within the scatter of the next).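

In this assay, chloro on an aromatic carbon para to a large group gives a step beyond the scatter (a number 21 percentage points higher from compound 3 to compound 4 (beyond the scatter)), so a higher number on the carbonyl side is no longer tied to a methoxy-bearing ring. The chloro and methoxy rings are not told apart at this position (a number 10 percentage points higher from compound 2 to compound 4 (within the scatter)), nor are the 4-chlorophenyl and 3-methoxyphenyl rings (a number 3 percentage points higher from compound 1 to compound 4 (within the scatter)), which leaves the bare phenyl of compound 3 as the only ring in these four compounds set apart from the rest. No supporting data accompany these numbers, so the step stands as an observation with no explanation attached.

Open, on these data alone, is whether an amine or a carboxylic acid on that same aromatic carbon would sit with the chloro and methoxy rings or with the bare phenyl of compound 3. Also open, as far as these compounds go, is what the other ring and its two methoxy groups contribute, as they stay the same in all four compounds.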